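The source may report more compounds than this note shows. Statements on the series, on what has been measured and on what is new or still open speak of the compounds shown alone.

Compound 1, `CCc1cnc(N2CCC(c3coc4c(N5CCc6cc(S(C)(=O)=O)ccc65)ncnc34)CC2)nc1`, is the point of departure. In a functional assay on cells for agonist activity at Glucose-dependent insulinotropic receptor (Homo sapiens), read by a luciferase reporter, with a stated time of 4 h (on this read-out lower numbers stand for smaller maximal responses and higher numbers for larger maximal responses), compound 1 reaches 154%, the highest of the three numbers in hand. Compound 3, `CC(C)(C)OC(=O)N1CCC(c2noc3c(Nc4ccc(S(C)(=O)=O)cc4F)ncnc23)CC1`, stands nearest to it: in this assay compound 3 reaches 137%, a gap beyond the usual scatter. Compound 2, `CC(C)(C)OC(=O)N1CCC(c2coc3c(Nc4ccc(S(C)(=O)=O)cc4F)ncnc23)CC1`, lies furthest away, since in this assay compound 2 reaches 123%, again beyond the scatter. No two of these three measured compounds differ in a single place, so no one-step comparison among them can be drawn.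

Compound 4, `CC(C)(C)OC(=O)N1CCC(c2coc3c(N4CCc5cc(S(C)(=O)=O)ccc54)ncnc23)CC1`, differs from compound 1 in one place: tert-butoxycarbonyl in place of 5-ethylpyrimidin-2-yl on an amine nitrogen in a ring. Compounds 2 and 3 carry the same tert-butoxycarbonyl on an amine nitrogen in a ring, though they differ from compound 4 elsewhere, so their numbers only hint at how this group fares. Those hints point downward, because compound 2 reaches 123% and compound 3 reaches 137%, both well under the mark of compound 1. For compound 4 the expected step is therefore a number 19 percentage points lower from compound 1 to compound 4 (beyond the scatter), a fall beyond the scatter. Compound 4 is estimated to reach 135% in this assay, with a likely range from 110% to 160%.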

Compound 4, largest response reached (Emax), in percent of the reference or control that the assay uses: 123%
The estimate for compound 4 lay 12 percentage points above the measured number; the range from low to high includes it.
By their numbers in this assay, from the lowest: compounds 2 and 4 (each within the scatter of the next); then compound 3; then compound 1.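

Within the data shown here, with the rest of compound 1 held fixed, this is the first direct reading of the group on the amine nitrogen in the six-membered non-aromatic ring: in this assay, tert-butoxycarbonyl in place of 5-ethylpyrimidin-2-yl gives a number 31 percentage points lower from compound 1 to compound 4 (beyond the scatter), a large step. Compounds 2 and 3 could only hint at this, as they also differ elsewhere, whereas here the fall belongs to this one exchange. It occurs with the counts of hydrogen-bond donors and acceptors unchanged, while a six-membered aromatic ring leaves and a group with no ring and a double bond outside aromatic rings enters, and nothing measured here explains the size of the step.

The compounds shown do not separate the contribution of the pyrimidine ring from that of its ethyl group, which a plain pyrimidin-2-yl or a 5-methylpyrimidin-2-yl on the same nitrogen would address. Whether the exchange carries the same weight on the cores of compounds 2 and 3 also remains open, as neither has a partner bearing 5-ethylpyrimidin-2-yl among the compounds shown.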